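Aryl-oxygen substituent change on the measured arylamide

The source may report more compounds than this note shows. Statements on the series, on what has been measured and on what is new or still open speak of the compounds shown alone.

Measured in an assay on HL-60 cells for agonist activity at vitamin D3 receptor (Homo sapiens), read by microscopy, with a stated time of 96 h; on this read-out lower numbers stand for an effect already at smaller amounts and higher numbers for an effect only at larger amounts of compound:
compound 1, `CCOC(=O)CN(C)C(=O)c1ccc(C(CC)(CC)c2ccc(OCC(=O)C(C)(C)C)c(C)c2)n1CC`: > 50000 nM, a limit of the assay.
compound 2, `CCn1c(C(=O)N(C)CC(=O)O)ccc1C(CC)(CC)c1ccc(OCC(=O)C(C)(C)C)c(C)c1`: 1390 nM.
compound 3, `CCn1c(C(=O)Nc2ccc(OC(F)(F)F)cc2)ccc1C(CC)(CC)c1ccc(OCC(=O)C(C)(C)C)c(C)c1`: > 50000 nM, a limit of the assay.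

Compound 3 stands at the limit of > 50000 nM in this assay, at which 2 of the 3 values shown sit, together with compound 1; only compound 2 gives a number. Compound 4, `CCOc1ccc(NC(=O)c2ccc(C(CC)(CC)c3ccc(OCC(=O)C(C)(C)C)c(C)c3)n2CC)cc1`, differs from compound 3 by ethyl in place of trifluoromethyl on an oxygen on an aromatic ring. Among the measured compounds shown here, none of the measured steps touches that position: an at least 35-fold lower number from compound 1 to compound 2 (1.55 log units; beyond the scatter) and an at least 35-fold higher number from compound 2 to compound 3 (1.55 log units; beyond the scatter) both concern the group on the carbonyl carbon, and a step that the two limits leave unreadable from compound 1 to compound 3 cannot be read between two limits. The step of an at least 35-fold higher number from compound 2 to compound 3 (1.55 log units; beyond the scatter) shows that putting (4-(trifluoromethoxy)phenyl)amino in place of (carboxymethyl)(methyl)amino carries the value out to the limit; compound 4 keeps the aryl amino group and changes only what sits on the aryl oxygen. For the measured compounds named here, nothing among the measured compounds indicates that ethyl for trifluoromethyl at that oxygen brings the value back into the readable range. The expectation is therefore that compound 4 also comes out at the limit, with a number no higher from compound 3 to compound 4 (the limit leaves the size open) not beyond the scatter. The estimated value for compound 4 is 50000 nM, within a range of 10000 nM to 200000 nM.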

Compound 4, half-maximal effective concentration: > 50000 nM
Compound 4 was reported as a limit; the forecaster's own chance of this, stated with the estimate: 70%; the middle value lies on the limit itself.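

In this assay compound 4 gives > 50000 nM, a limit of the assay and not a number. Among the compounds shown here, the one readable comparison is an at least 35-fold higher number from compound 2 to compound 4 (1.55 log units; beyond the scatter), so replacing (carboxymethyl)(methyl)amino on the carbonyl carbon with an aryl amino group now leads to the limit with ethoxy as well as with trifluoromethoxy on the aromatic ring. The steps from compound 3 and from compound 1 to compound 4 cannot be read, so the change from trifluoromethyl to ethyl on this oxygen has no readable size, and the series gathers at one end: the limit of > 50000 nM in this assay, at which 3 of the 4 values shown sit.

Compound 2 remains the only compound here with a number, 1390 nM, so the compounds shown give no readable baseline for any change on the aryl oxygen. Going by these compounds, it stays open whether an arylamide with an amine in place of ethoxy, or with a carboxylic acid carried on a longer chain in place of ethyl, would return to the readable range of this assay.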